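The compounds below may be only part of what the source reports. "The series", "measured", "known", "first", "only" and "open" are said of these compounds alone.

Measured compounds:
compound 1, `COc1cc(/C=C/C(=O)O/N=C/c2ccccn2)cc(OC)c1OC`, 787000 nM
compound 2, `O/N=C/c1ccco1`, 475000 nM
compound 3, `COc1ccc(/C=C/C(=O)O/N=C/c2ccco2)cc1OC`, 624000 nM

In an ADME assay on HepG2 2.2.15 cells (Homo sapiens) for cytotoxicity, read by MTT assay, with a stated time of 9 days (on this read-out higher numbers stand for lower toxicity in this test and lower numbers for higher toxicity in this test), compound 3 gives 624000 nM, the second highest of the three numbers. Its nearest neighbour is compound 1, whose value of 787000 nM lies within the scatter, and compound 2, at 475000 nM, is also within the scatter of compound 3. All three measured compounds therefore stand at much the same level in this assay, and no ordering among them can be claimed.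

Compound 4, `COc1cc(/C=C/C(=O)O/N=C/c2ccco2)cc(OC)c1OC`, is not yet measured. It differs from compound 3 in one place: methoxy in place of hydrogen on an aromatic carbon. The new group sits on an aromatic carbon of a six-membered aromatic ring of carbon only, ortho to a methoxy group and meta to a large group.

Among the compounds with values here, no measured pair shows what this change does. Compound 1 already carries the same arrangement of methoxy groups and sits within the scatter of compound 3, so compound 4 is expected to show no step beyond the scatter, a 1.1-fold higher number from compound 3 to compound 4 (0.05 log units; within the scatter). Compound 4 is estimated at 700000 nM, between 350000 nM and 1400000 nM.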

Compound 4, half-maximal cytotoxic concentration: 1050000 nM
Beside the measured number, compound 4's estimate is 1.5-fold (0.18 log units) below it, and the stated range covers the measured number.
By their numbers in this assay, from the lowest: compounds 2, 3, 1 and 4 (each within the scatter of the next, the first and the last beyond it).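

In this assay, methoxy in place of hydrogen on an aromatic carbon, ortho to a methoxy group and meta to a large group, can now be read directly as a 1.7-fold higher number from compound 3 to compound 4 (0.23 log units; within the scatter) and lies within the scatter, so this test separates no effect of the change at this position. The other new pair, which carries the same arrangement of methoxy groups and differs by furan-2-yl in place of pyridin-2-yl on a carbon with a double bond to nitrogen, gives a 1.3-fold higher number from compound 1 to compound 4 (0.13 log units; within the scatter) and also lies within the scatter. Nothing measured here bears on why these steps are as they are.

Going by these compounds, whether an ethoxy group, an amine or a carboxylic acid at this position would give a step beyond the scatter remains open. So does whether the methoxy step would read the same with pyridin-2-yl in place of furan-2-yl.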